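The source may hold more compounds than are shown below. What is called first, only, known or untested is meant among the compounds shown, and "the series" means these compounds.

Measured in a functional assay on RPMI-8226 cells (Homo sapiens) for cytotoxicity, read by MTT assay, with a stated time of 48 h; on this read-out lower numbers stand for stronger inhibition and higher numbers for weaker inhibition:
- Compound 1 `CC(C)(C)NN=C1C(Cl)=C(Cl)C(Cl)=C1Cl`: > 3000 nM
- Compound 2 `CC(=O)NN=C1C(Cl)=C(Cl)C(Cl)=C1Cl`: 1000 nM

Compound 1 has the entry > 3000 nM, which is a limit of the assay and not a number. Among the compounds with values here, compound 2, at 1000 nM, therefore holds the only true number so far.

The next compound to be tested is compound 3 `CN(C)N=C1C(Cl)=C(Cl)C(Cl)=C1Cl`. It carries dimethylamino in place of acetamido on a double-bonded nitrogen. This removes the acetyl part of compound 2, and compound 1 has no acetyl group either.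

Within the data shown here, the one measured step that bears on this change is an at least 3.0-fold lower number from compound 1 to compound 2 (0.47 log units; beyond the scatter). Among the measured compounds shown here, this is only a single comparison, and the groups in compound 3 and compound 1 are not the same, so it gives direction more than exact size. If the same trend holds, losing the acetyl should move the number up by a modest amount.

The expected change is a 2.5-fold higher number from compound 2 to compound 3 (0.40 log units; beyond the scatter), towards weaker inhibition. For compound 3 the estimated value is 2500 nM, with an expected range of 900 nM to 7000 nM.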

Compound 3, half-maximal inhibitory concentration: >= 1300 nM
Compound 3: only a limit was reported; the forecaster's own chance of this, stated with the estimate: 45%; the middle value is on the limit's open side.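

In this assay compound 3 gives >= 1300 nM, which is a limit of the assay and not a number. Replacing acetamido with dimethylamino on a double-bonded nitrogen gives an at least 1.3-fold higher number from compound 2 to compound 3 (0.11 log units; that floor lies within the scatter), so the data cannot separate a real loss of activity from little or no change, and the true value of compound 3 could lie close to that of compound 2 or well beyond it. What is new is that a second compound without the acetyl part, of a different shape from compound 1, also yields no true number, although the step between compound 1 and compound 3 cannot be read, as both entries are limits: the limit of >= 1300 nM in this assay, at which 1 of the 3 values shown sits.

Still open, on these data alone, is what the acetamido group of compound 2 contributes, since the comparison does not tell whether the carbonyl, the amide hydrogen or the whole group matters. Placing a methylamino group or a longer acyl chain such as propionyl on the same nitrogen would test these parts separately, and a true number for compound 3 would be needed to size the step.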